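The source may hold more compounds than are shown below. What is called first, only, known or untested is meant among the compounds shown, and "the series" means these compounds.

Compound 1, `O=C(CCC1=CCN(CCCc2ccc(Br)cc2)C1=O)NO`, gives 2210 nM in a functional assay on MDA-MB-231 cells (Homo sapiens) for inhibition, read by sulforhodamine B assay; a lower number here means a stronger inhibitor of growth, a higher number a weaker inhibitor of growth.
Compound 2, `CCOc1ccc(CCCN2CC=C(CCC(=O)NO)C2=O)cc1`, gives 2210 nM in this assay.
Compound 3, `CC(C)(C)c1ccc(CCCN2CC=C(CCC(=O)NO)C2=O)cc1`, gives 2210 nM in this assay.

Compound 3 stands level with compounds 1 and 2: no change at the digits printed from compound 1 to compound 3 (within the scatter) and no change at the digits printed from compound 2 to compound 3 (within the scatter), just as no change at the digits printed from compound 1 to compound 2 (within the scatter). Compound 4, `CC(C)c1ccc(CCCN2CC=C(CCC(=O)NO)C2=O)cc1`, is not yet measured. Its change from compound 3 is hydrogen in place of methyl on a saturated chain carbon bound to an aromatic carbon and two saturated chain carbons. Among the compounds with values here, none of the measured steps touches this saturated chain carbon; they all swap the group on the aromatic carbon, and every one of them stays within the scatter. There is thus no sign that this part of the structure moves the number, so the expected step of no change at the digits printed from compound 3 to compound 4 (within the scatter) is none beyond the scatter. Compound 4 is therefore estimated at 2210 nM, with a range from 1100 nM to 4400 nM.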

Compound 4, concentration for 50% growth inhibition: 2210 nM
Estimate against measurement, compound 4: no gap at the digits printed, and the stated range covers the measured number.
By their numbers in this assay, from the lowest: compounds 1, 2, 3 and 4 (each within the scatter of the next).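

Hydrogen in place of methyl, which turns tert-butyl into isopropyl, gives no change at the digits printed from compound 3 to compound 4 (within the scatter) in this assay, the first reading of a change within this group itself rather than a swap of the whole group. Isopropyl in place of ethoxy gives no change at the digits printed from compound 2 to compound 4 (within the scatter) and isopropyl in place of bromo gives no change at the digits printed from compound 1 to compound 4 (within the scatter), so isopropyl fits with the other three groups on this aromatic carbon.

On these data alone, whether an amine, a carboxylic acid or a longer chain on that carbon would read the same remains open. No measurement shown offers a reason for these matching numbers.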